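The compounds below may be only part of what the source reports. "The series", "measured", "known", "first", "only" and "open" are said of these compounds alone.

Compound 1 `COc1ccc(CN(C(=O)CCCl)c2cc(OC)c(OC)c(OC)c2)cc1O` is the stronger of the two measured compounds: in a functional assay on MGC-803 cells (Homo sapiens) for inhibition, read by MTT assay, with a stated time of 48 h (on this read-out lower numbers stand for stronger inhibition and higher numbers for weaker inhibition), compound 1 gives 140 nM, while compound 2 `COc1ccc(CNc2cc(OC)c(OC)c(OC)c2)cc1` gives 11400 nM, a gap far beyond the usual scatter. Compound 3 `COc1ccc(CN(C(=O)/C=C/CBr)c2cc(OC)c(OC)c(OC)c2)cc1O` is compound 1 with one change, (3-bromoprop-1-en-1-yl in place of 2-chloroethyl on a carbonyl carbon). Nothing measured here speaks directly to this change, so the step from compound 1 to compound 3 is expected to be small and within the scatter, as a 1.3-fold lower number from compound 1 to compound 3 (0.10 log units; within the scatter). Compound 3 is therefore estimated at 110 nM in this assay, with a range from 30 nM to 400 nM.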

Compound 3, half-maximal inhibitory concentration: 71 nM
Estimate against measurement, compound 3: 1.5-fold (0.19 log units) above; measured number inside the range.
By their numbers in this assay, from the lowest: compounds 3 and 1 (each within the scatter of the next); then compound 2.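

In this assay the change from 2-chloroethyl to 3-bromoprop-1-en-1-yl on the carbonyl carbon gives a 2.0-fold lower number from compound 1 to compound 3 (0.29 log units; within the scatter) and so shows that this position tolerates a chain with one more carbon, a double bond and bromine in place of chlorine. The step combines these three differences and cannot separate them. No measurement shown explains the result. Still open, on these data alone, is whether the double bond or the bromine matters more, which 3-chloroprop-1-en-1-yl could test. Also open, as far as these compounds go, is how an amine or a carboxylic acid at the chain end would fare.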